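Nitro for hydrogen on the aryl of a pyrazoline thiourea

The source may report more compounds than this note shows. Statements on the series, on what has been measured and on what is new or still open speak of the compounds shown alone.

Measured so far:
compound 1 `S=C(Nc1ccccc1)N1N=C(c2ccccc2)CC1c1ccc2c(c1)OCCO2`: 3180 nM
compound 2 `CSc1ccc(C2=NN(C(=S)Nc3ccccc3)C(c3ccc4c(c3)OCCO4)C2)cc1`: 197000 nM

In a functional assay on WM 266-4 cells (Homo sapiens) for antiproliferative activity, read by MTT assay, with a stated time of 48 h (on this read-out higher numbers stand for weaker inhibition of growth and lower numbers for stronger inhibition of growth), compound 1 gives the lowest of the two numbers; compound 2 sits well apart from it, at 197000 nM. For the measured compounds named here, the single measured step, a 62-fold higher number from compound 1 to compound 2 (1.79 log units; beyond the scatter), concerns the same aromatic carbon that is altered here and is the only step that bears on the present change.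

Compound 3 `O=[N+]([O-])c1ccc(C2=NN(C(=S)Nc3ccccc3)C(c3ccc4c(c3)OCCO4)C2)cc1` differs from compound 1 by nitro in place of hydrogen on an aromatic carbon. Going by the values given here, the nitro group is not the methylsulfanyl group, so the size of the one known step cannot simply be carried over, but it is the only guide, and it points to a weaker inhibition of growth in this assay for compound 3 than for compound 1, by a step beyond the scatter. The step implied by this estimate is a 6.3-fold higher number from compound 1 to compound 3 (0.80 log units; beyond the scatter). For compound 3 the expected value in this assay is 20000 nM, within a range of 3000 nM to 150000 nM.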

Compound 3, concentration for 50% growth inhibition: 105000 nM
For compound 3 the middle estimate is 5.3-fold (0.72 log units) below the measured one, within the range that was stated.
By their numbers in this assay, from the lowest: compound 1; then compounds 3 and 2 (each within the scatter of the next).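

In this assay, a second group on this aromatic carbon also gives a number far above that of the unsubstituted compound, with nitro for hydrogen producing (a 33-fold higher number from compound 1 to compound 3 (1.52 log units; beyond the scatter)). Exchanging one group for the other produces (a 1.9-fold lower number from compound 2 to compound 3 (0.27 log units; within the scatter)), so nitro and methylsulfanyl cannot be told apart here, while compound 1, with hydrogen on this carbon, keeps the lowest number of the three. No measurement on hand accounts for the shift seen with either group.

The compounds shown leave open whether fluorine, a methyl group, an amine or a carboxylic acid on this same carbon would give a number near that of compound 1 or near those of the two substituted compounds. They also leave open whether nitro on another carbon of this ring would give the same shift.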